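The source may report more compounds than this note shows. Statements on the series, on what has been measured and on what is new or still open speak of the compounds shown alone.

Measured compounds:
- compound 1, `COc1ccc(N2CCn3nc(COc4ccccc4)cc3C2=O)nc1`: 74%
- compound 2, `O=C1c2cc(COc3ccc(F)cc3)nn2CCN1c1ccc(F)cc1`: 72%

In a functional assay on HEK293 cells for positive allosteric modulation of metabotropic glutamate receptor 5 (Homo sapiens), read by calcium flux (on this read-out lower numbers stand for smaller maximal responses and higher numbers for larger maximal responses), compound 1 reaches 74% and compound 2 reaches 72%; the two numbers lie within the usual scatter of each other, so no ordering between compound 1 and compound 2 can be read from them. Compound 2 is the point of departure for the next compound.

Compound 3, `O=C1c2cc(COc3cccnc3)nn2CCN1c1ccc(F)cc1`, differs from compound 2 in one place: pyridin-3-yl in place of 4-fluorophenyl on an oxygen on a saturated carbon. The change is confined to the group on the oxygen on a saturated carbon; the rest of the shared core is kept. For the measured compounds named here, no measured pair tells how such an exchange plays out, so there is nothing to lean on beyond the two values shown.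

For compound 3 the expectation is a step of a number 4 percentage points lower from compound 2 to compound 3 (within the scatter) of no more than the scatter, if anything downward. Compound 3 is estimated at 68%, with a range from 50% to 85%.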

Compound 3, largest response reached (Emax), in percent of the reference or control that the assay uses: 69%
Compound 3: the middle estimate sits 1 percentage points below what was measured; measured number inside the range.
By their numbers in this assay, from the lowest: compounds 3, 2 and 1 (each within the scatter of the next).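

In this assay, pyridin-3-yl in place of 4-fluorophenyl on an oxygen on a saturated carbon gives a number 3 percentage points lower from compound 2 to compound 3 (within the scatter). This first single-place exchange in the series shows that, at this position, a six-membered aromatic ring with one hetero atom and one hydrogen-bond acceptor can replace the carbon-only ring without a step beyond the scatter. No independent measurement bears on this result.

Still open, as far as these compounds go, is whether this tolerance extends to pyrimidin-5-yl or to a non-aromatic group such as piperidin-4-yl, or a longer chain carrying a carboxylic acid, on the same oxygen. Also open, from the compounds shown here alone, is whether the same exchange gives a comparable step when the 4-fluorophenyl elsewhere on the shared core is replaced.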